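This account rests on a few compounds, and the source may have more. Where it says the series, first, only, none or still open, it means among the compounds named here.

Of the compounds shown here, two sharing one core have been measured so far. Compound 1 `O=C(Nc1cc(Sc2ncn[nH]2)c(O)c2ccccc12)c1ccc([N+](=O)[O-])cc1` carries a 4-nitrophenyl on the carbonyl carbon. In a functional assay on HCT-116 cells (Homo sapiens) for antiproliferative activity, read by MTT assay, with a stated time of 48 h (on this read-out lower numbers stand for stronger inhibition and higher numbers for weaker inhibition), compound 1 gives > 100000 nM, which is a limit of the assay and not a number. Compound 2 `O=C(/C=C/c1ccccc1)Nc1cc(Sc2ncn[nH]2)c(O)c2ccccc12` carries a 2-phenylethenyl in that place. In this assay compound 2 gives > 100000 nM, again only a limit. The step that the two limits leave unreadable from compound 1 to compound 2 cannot be read in size or direction because of the limit of > 100000 nM in this assay, at which 2 of the 2 values shown sit. Compound 2 therefore stands only at the edge of what the assay can report, with no measured number to set against compound 1.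

Compound 3 `COc1ccc(C(=O)Nc2cc(Sc3ncn[nH]3)c(O)c3ccccc23)cc1` differs from compound 2 by 4-methoxyphenyl in place of 2-phenylethenyl on a carbonyl carbon whose other neighbour is an amide-type nitrogen. Among the compounds with values here, the one measured step, from compound 1 to compound 2, concerns a change at the same carbonyl carbon, yet its size is unreadable. With neither measured compound reaching a number, no step beyond the scatter is expected in this assay. The expected step of a number no higher from compound 2 to compound 3 (the limit leaves the size open) is estimated to be flat. Compound 3 is expected to give 100000 nM, within a range from 20000 nM to 300000 nM, most probably again as a limit.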

Compound 3, half-maximal inhibitory concentration: > 100000 nM
Compound 3 was reported as a limit; the forecaster's own chance of this, stated with the estimate: 70%; the middle value lies on the limit itself.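

In this assay compound 3 gives > 100000 nM, which is a limit of the assay and not a number. Within the data shown here, no step among compound 1, compound 2 and compound 3 can be read in size or direction: the limit of > 100000 nM in this assay, at which 3 of the 3 values shown sit. The compounds shown leave open whether any group on this carbonyl carbon of the shared core would give a measured number.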